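The source may report more compounds than this note shows. Statements on the series, on what has been measured and on what is new or still open speak of the compounds shown alone.

Going by the values given here, in a functional assay on DU-145 cells (Homo sapiens) for inhibition, read by trypan blue exclusion, with a stated time of 96 h (a higher number here means a weaker inhibitor of growth, a lower number a stronger inhibitor of growth), compound 2 `O=C(/C(=C\c1c(O)cc(O)cc1O)SCc1ccc(Cl)c(Cl)c1)c1ccc(Cl)cc1` gives 25000 nM, the only actual number so far. Compound 1 `Cc1ccc(S/C(=C/c2c(O)cc(O)cc2O)C(=O)c2ccc(Cl)cc2)cc1` gives > 100000 nM, which is a limit of the assay and not a number. Compound 3 `O=C(/C(=C\c1c(O)cc(O)cc1O)Sc1ccccc1Br)c1ccc(Cl)cc1` carries 2-bromophenyl in place of 3,4-dichlorobenzyl on a sulfur. A single measured step bears on this change, an at least 4.0-fold lower number from compound 1 to compound 2 (0.60 log units; beyond the scatter), in which 3,4-dichlorobenzyl replaced 4-methylphenyl on a sulfur and the number fell beyond the scatter. As far as these compounds go, that step rests on a limit, so its full size is unknown. With a phenyl group back on the sulfur, the number in this assay is expected to rise on the evidence of an at least 4.0-fold lower number from compound 1 to compound 2 (0.60 log units; beyond the scatter), meaning weaker growth inhibition. The expected change is a 2.0-fold higher number from compound 2 to compound 3 (0.30 log units; within the scatter). The value for compound 3 is estimated at 50000 nM, within a range from 15000 nM to 150000 nM.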

Compound 3, concentration for 50% growth inhibition: > 100000 nM
Compound 3: a limit, no number (the forecaster's own chance of this, stated with the estimate: 35%); at least 2.0-fold (0.30 log units) between middle value and limit.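

In this assay compound 3 gives > 100000 nM, which is a limit of the assay and not a number. Exchanging 3,4-dichlorobenzyl for 2-bromophenyl on the sulfur gives an at least 4.0-fold higher number from compound 2 to compound 3 (0.60 log units; beyond the scatter), so this position now has a measured loss in both directions around compound 2, and the change to a bromine-bearing phenyl group does not recover a readable number. Only compound 2, with its 3,4-dichlorobenzyl group, gives a number, while the step between the two phenyl compounds, compound 1 and compound 3, cannot be read: the limit of > 100000 nM in this assay, at which 2 of the 3 values shown sit.

The compounds shown leave open whether the number for compound 2 goes with the benzyl link to the sulfur or with its chlorines. A plain benzyl or a 2-bromobenzyl group on the sulfur would separate these two readings.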